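A few compounds are considered here, and "the series" means these few. Any claim that something is new, unique, unknown or untested is made for them only; others in the source may bear on it.

Of the compounds shown here, three have been measured so far. Compound 1 `COc1cccc(Nc2nccc(-c3ccncc3)n2)c1` gives 400 nM in a functional assay for inhibition, with Homo sapiens as the target (a lower number here means a stronger inhibitor, a higher number a weaker inhibitor), and compound 2 `Cc1cc(C)cc(Nc2nccc(-c3cccnc3)n2)c1` gives 800 nM. Compound 3 `CCc1ccc(Nc2nccc(-c3ccncc3)n2)cc1` gives 7700 nM, the highest of the three numbers and therefore the weakest inhibitor shown here; its steps to compound 2 and to compound 1 both lie beyond the usual scatter. The step to compound 4 `Cc1cn(-c2ccc(Nc3nccc(-c4ccncc4)n3)cc2)cn1` changes one spot on the shared core: 4-methyl-1H-imidazol-1-yl in place of ethyl on an aromatic carbon. Within the data shown here, no measured pair shows this change, so its effect can only be guessed. A moderate move toward a lower number, beyond the scatter, is expected, with an estimated step of a 3.9-fold lower number from compound 3 to compound 4 (0.59 log units; beyond the scatter). Compound 4 is expected to give about 2000 nM, within a range of 500 nM to 8000 nM.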

Compound 4, half-maximal inhibitory concentration: > 3000 nM
Compound 4: only a limit was reported; the forecaster's own chance of this, stated with the estimate: 5%; at least 1.5-fold (0.17 log units) between middle value and limit.
By their numbers in this assay, from the lowest: compounds 1 and 2 (each within the scatter of the next); then compound 3.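

In this assay compound 4 gives > 3000 nM, which is a limit and not a number. The step from compound 3 to compound 4 cannot be read. The compounds shown leave open what 4-methyl-1H-imidazol-1-yl in place of ethyl does to inhibition.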